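Chloro for Hydrogen on the Benzyl Group of Compound 1

A few compounds are considered here, and "the series" means these few. Any claim that something is new, unique, unknown or untested is made for them only; others in the source may bear on it.

Measured compounds:
compound 1 `O=C1NC(=O)/C(=C/c2cn(Cc3ccccc3)c3ccccc23)N1` gives > 40000 nM in a functional assay on A549 cells (Homo sapiens) for antiproliferative activity, read by trypan blue exclusion, with a stated time of 24 h (on this read-out lower numbers stand for stronger inhibition and higher numbers for weaker inhibition), a limit rather than a number.
compound 2 `O=C1NC(=O)/C(=C/c2cn(Cc3ccc([N+](=O)[O-])cc3)c3ccccc23)N1` gives > 40000 nM in this assay, likewise only a limit.

Compound 1 thus stands at a limit, not at a measured number. Among the compounds with values here, the single step measured, a step that the two limits leave unreadable from compound 1 to compound 2, cannot be read because of the limit of > 40000 nM in this assay, at which 2 of the 2 values shown sit. Compound 3 `O=C1NC(=O)/C(=C/c2cn(Cc3ccc(Cl)cc3)c3ccccc23)N1` differs from compound 1 by chloro in place of hydrogen on an aromatic carbon. No readable step bears on this change, so no direction beyond the scatter can be expected. Compound 3 is therefore expected to stay where compound 1 stands, an expected step of a number no higher from compound 1 to compound 3 (the limit leaves the size open). Compound 3 is estimated at 40000 nM, between 15000 nM and 100000 nM, most likely reported again only as a limit.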

Compound 3, half-maximal inhibitory concentration: 25400 nM
Beside the measured number, compound 3's estimate is 1.6-fold (0.20 log units) above it, within the range that was stated.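

In this assay, the change from benzyl to 4-chlorobenzyl yields the only actual number among the compounds shown, not another limit (an at least 1.5-fold lower number from compound 1 to compound 3 (0.19 log units; that floor lies within the scatter)). Chloro in place of nitro on the same aromatic carbon gives a step of the same printed floor (an at least 1.5-fold lower number from compound 2 to compound 3 (0.19 log units; that floor lies within the scatter)). On these data alone, both steps are only floors, so their true size stays unknown: the limit of > 40000 nM in this assay, at which 2 of the 3 values shown sit.

As far as these compounds go, whether a methoxy group, an amine or a carboxylic acid on that carbon would shift the number further remains open, as does the effect of chloro elsewhere on that ring.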